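Working notes: fluoro in place of hydrogen, compound 2 to 3

A few compounds are considered here, and "the series" means these few. Any claim that something is new, unique, unknown or untested is made for them only; others in the source may bear on it.

Measured so far:
compound 1 `COc1ccc2c(C(=O)/C(C#N)=C/c3c[nH]c4cc(F)ccc34)c[nH]c2c1`, 800 nM
compound 2 `N#C/C(=C\c1c[nH]c2ccccc12)C(=O)c1c[nH]c2ccccc12`, 22000 nM

For the measured compounds named here, in a functional assay on A549 cells (Homo sapiens) for cytotoxicity, read by WST assay, with a stated time of 48 h (a lower number here means a stronger inhibitor, a higher number a weaker inhibitor), compound 2 gives 22000 nM, the highest of the two numbers; compound 1 gives 800 nM, but compound 1 differs from compound 2 in more than one place, so no single step is known. Compound 3 `N#C/C(=C\c1c[nH]c2cc(F)ccc12)C(=O)c1c[nH]c2ccccc12` differs from compound 2 by fluoro in place of hydrogen on an aromatic carbon. Going by the values given here, no measured step matches this change, so any expectation rests on the gap between compound 2 and compound 1 alone. A moderate step toward a lower number is expected, a 2.2-fold lower number from compound 2 to compound 3 (0.34 log units; beyond the scatter), with wide uncertainty. Compound 3 is estimated at 10000 nM, within 3000 nM to 30000 nM.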

Compound 3, half-maximal inhibitory concentration: 22700 nM
The estimate for compound 3 lay 2.3-fold (0.36 log units) below the measured number; the measured number falls inside the stated range.
By their numbers in this assay, from the lowest: compound 1; then compounds 2 and 3 (each within the scatter of the next).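

In this assay fluoro in place of hydrogen on this aromatic carbon gives a 1.0-fold higher number from compound 2 to compound 3 (0.01 log units; within the scatter) and so does not separate the two compounds. Hydrogen in place of methoxy gives a 28-fold higher number from compound 1 to compound 3 (1.45 log units; beyond the scatter) with the fluoro kept, so in this pair the large gap goes with the methoxy group. No measurement here bears on why either step has this size.

Going by these compounds, whether fluoro at this position matters once methoxy is present stays open. So does the outcome with an amine or a hydroxyl group in place of methoxy, or with chloro in place of fluoro.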